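Aryl Sulfonamide Exchange on a Thromboxane Receptor Antagonist

The compounds below may be only part of what the source reports. "The series", "measured", "known", "first", "only" and "open" are said of these compounds alone.

Of the compounds shown here, three have been measured in a functional assay on a cell-free system (plasma) for inhibition of thromboxane A2 receptor (Homo sapiens), read by turbidimetry; a lower number here means a stronger inhibitor, a higher number a weaker inhibitor. Compound 1 `Cc1ccc(S(=O)(=O)N[C@H]2CC[C@@H](F)[C@@H]2C/C=C\CCCC(=O)O)cc1` gives 260 nM. Compound 2 `O=C(O)COCCCC[C@H]1[C@H](F)CC[C@@H]1NS(=O)(=O)c1ccc(F)cc1F` gives 1800 nM, and compound 3 `O=C(O)COCCCCC1=CCC[C@@H]1NS(=O)(=O)c1ccc(Cl)c(Cl)c1` gives 1900 nM. Among these three numbers compound 2 holds the second highest; its value and that of compound 3 lie within the scatter of each other, so nothing separates them, whereas the number for compound 1 lies beyond the scatter below that of compound 2. Compound 1 and compound 2 differ in more than one place, so no single change can be read from that gap.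

Compound 4 `Cc1ccc(S(=O)(=O)N[C@H]2CC[C@@H](F)[C@@H]2CCCCOCC(=O)O)cc1` is the next compound to be measured. Relative to compound 2, the change is 4-methylphenyl in place of 2,4-difluorophenyl on a sulfonyl sulfur. Among the measured compounds shown here, no measured pair isolates this change. Because compound 1 with the same 4-methylphenyl group gives 260 nM, a downward step in this assay is expected for compound 4, though the chain of compound 4 matches compound 2 rather than compound 1. The expected step is a 2.6-fold lower number from compound 2 to compound 4 (0.41 log units; beyond the scatter), beyond the usual scatter but short of the whole gap seen so far. Compound 4 is therefore estimated at 700 nM, within a range of 250 nM to 2000 nM.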

Compound 4, half-maximal inhibitory concentration: 1800 nM
The estimate for compound 4 lay 2.6-fold (0.41 log units) below the measured number; measured number inside the range.
By their numbers in this assay, from the lowest: compound 1; then compounds 2, 4 and 3 (each within the scatter of the next).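

In this assay, the aryl group on the sulfonyl sulfur can now be read on its own: 4-methylphenyl in place of 2,4-difluorophenyl leaves the number unmoved (no change at the digits printed from compound 2 to compound 4 (within the scatter)). The 4-methylphenyl group therefore does not bring the low number of compound 1 with it on this chain. With that group held fixed, 3-(carboxymethoxy)propyl in place of 5-carboxypent-1-en-1-yl gives a clear step (a 6.9-fold higher number from compound 1 to compound 4 (0.84 log units; beyond the scatter)), and no measured property is available to explain either step.

The compounds shown leave open whether 2,4-difluorophenyl and 4-methylphenyl would also match on the 5-carboxypent-1-en-1-yl chain. On these data alone, it also remains open whether a methoxy-substituted phenyl or a thiophene ring on the sulfonyl sulfur would shift the number on either chain.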